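The source may report more compounds than this note shows. Statements on the series, on what has been measured and on what is new or still open speak of the compounds shown alone.

Measured so far:
- compound 1, `COc1ccccc1-n1cc(COc2c(/C=C\C(=O)O)ccc(OC)c2CC=C(C)C)nn1`: 32600 nM
- compound 2, `COc1ccc(-n2cc(COc3c(/C=C\C(=O)O)ccc(OC)c3CC=C(C)C)nn2)cc1`: "not determined" (no result reported)

Both compounds share one core and differ only in the aryl group on the triazole nitrogen. In a functional assay on A-431 cells (Homo sapiens) for cytotoxicity, read by MTT assay, with a stated time of 24 h (a higher number here means a weaker inhibitor, a lower number a stronger inhibitor), compound 1 gives 32600 nM, a weak effect. For compound 2 the entry in this assay is "not determined" (no result reported), so it stands nowhere on the scale shown, and nothing can be said about how it compares with compound 1.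

Compound 3, `COc1ccc(/C=C\C(=O)O)c(OCc2cn(-c3ccccc3I)nn2)c1CC=C(C)C`, differs from compound 2 in one place: 2-iodophenyl in place of 4-methoxyphenyl on an aromatic nitrogen. Among the measured compounds shown here, no measured step between two compounds of this kind exists here, so the size of the change cannot be read off. Given that compound 1 with its own aryl group is weak in this assay, compound 3 is expected to land in the same weak region, with any difference from compound 2 most likely no larger than the ordinary scatter. The estimate for compound 3 in this assay is 30000 nM, with a range from 8000 nM to 100000 nM.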

Compound 3, half-maximal inhibitory concentration: 32700 nM
For compound 3 the middle estimate is 1.1-fold (0.04 log units) below the measured one; measured number inside the range.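

In this assay, iodo in place of methoxy on an aromatic carbon of the aryl group gives a 1.0-fold higher number from compound 1 to compound 3 (0.00 log units; within the scatter). Among the compounds shown here, this is the first readable comparison at this position, and it shows that the two groups cannot be told apart here: with either one, the compound stays in the same weak region. Nothing available here accounts for this result.

Going by these compounds, the step from compound 2 to compound 3 cannot be read, as compound 2 has no number, and the effect of the 4-methoxyphenyl group therefore stays unknown. Also open, on these data alone, is whether a plain phenyl group, or an aryl group carrying an amine or a nitrile, would move the number beyond the usual scatter.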